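Swapping a ring amine for an ether on the shared core

This account rests on a few compounds, and the source may have more. Where it says the series, first, only, none or still open, it means among the compounds named here.

Measured compounds in an assay on CHO cells for antagonist activity at transient receptor potential cation channel subfamily V member 1 (Homo sapiens), read by FLIPR; a lower number here means a stronger inhibitor, a higher number a weaker inhibitor:
- compound 1, `CC(C(=O)NCc1ccc(C(F)(F)F)cc1N1CCCC1)c1ccc(NS(C)(=O)=O)c(F)c1`, gives 2.3 nM
- compound 2, `Cc1ccc(N2CCN(c3cc(C(F)(F)F)ccc3CNC(=O)C(C)c3ccc(NS(C)(=O)=O)c(F)c3)CC2)cc1`, gives 0.7 nM
- compound 3, `Cc1cccc(N2CCN(c3cc(C(F)(F)F)ccc3CNC(=O)C(C)c3ccc(NS(C)(=O)=O)c(F)c3)CC2)c1`, gives 1.8 nM

Among these three numbers, compound 1 has the highest. Its nearest neighbour is compound 3, whose number lies within the usual scatter of compound 1, so the two cannot be ranked against each other. Compound 2 gives a lower number, and that gap lies beyond the scatter.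

Compound 4, `CC(C)COc1cc(C(F)(F)F)ccc1CNC(=O)C(C)c1ccc(NS(C)(=O)=O)c(F)c1`, has not yet been measured. It differs from compound 1 in one place: isobutoxy in place of pyrrolidin-1-yl on an aromatic carbon. The group that leaves and the group that enters have the same count of heavy atoms and the same count of hydrogen-bond acceptors; the ring is lost and an open chain takes its place.

Among the measured compounds shown here, the only measured step, a 2.6-fold higher number from compound 2 to compound 3 (0.41 log units; beyond the scatter), concerns a different part of the molecule and so gives no guidance on this exchange. For the measured compounds named here, nothing among the measured compounds bears directly on replacing pyrrolidin-1-yl with isobutoxy. The step is therefore expected to be small, within or close to the scatter, in either direction, with a wide range to reflect the lack of a precedent. Compound 4 is expected to give 3 nM, within 1 nM to 10 nM. This estimate means the step of a 1.3-fold higher number from compound 1 to compound 4 (0.12 log units; within the scatter) is expected.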

Compound 4, inhibition constant: 0.8 nM
Estimate against measurement, compound 4: 3.8-fold (0.57 log units) above; measured number below the stated range.
By their numbers in this assay, from the lowest: compounds 2 and 4 (each within the scatter of the next); then compounds 3 and 1 (each within the scatter of the next).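

In this assay, the open chain attached through oxygen gives a 2.9-fold lower number from compound 1 to compound 4 (0.46 log units; beyond the scatter), so this aromatic carbon accepts isobutoxy in place of pyrrolidin-1-yl, even though the two groups have the same count of heavy atoms and of hydrogen-bond acceptors. Among the compounds shown here, all the earlier compounds carry a ring amine at this position, whereas compound 4, at 0.8 nM, shows that neither a ring nor a nitrogen in the group is needed for a low number here. This one exchange alters both the attached atom and the ring, and nothing in the data available explains the change in number.

On these data alone, it remains open which of those two alterations carries the step: a cyclopentyloxy group would keep a ring while attaching through oxygen, and an isobutylamino group would keep the open chain while attaching through nitrogen. As far as these compounds go, the length of the chain on oxygen is also open, from a short methoxy group to a longer hexyloxy chain, and so is whether a charged group such as a carboxylic acid would fit at this position.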